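The source may hold more compounds than are shown below. What is called first, only, known or untested is meant among the compounds shown, and "the series" means these compounds.

In a functional assay, with a stated time of 30 min (a lower number here means a stronger inhibitor, a higher number a weaker inhibitor), compound 1 `COc1cc([C@@H](O)[C@H](CO)Oc2c(OC)cc([C@@H](O)[C@H](O)CO)cc2OC)ccc1O` gives 10700 nM while compound 2 `CCO[C@H](c1ccc(O[C@@H](CO)[C@@H](O)c2ccc(O)c(OC)c2)c(OC)c1)[C@H](CO)c1ccc(O)c(OC)c1` gives 7900 nM and compound 3 `CCO[C@H](c1ccc(O[C@@H](CO)[C@@H](OC)c2ccc(O)c(OC)c2)c(OC)c1)[C@H](CO)c1ccc(O)c(OC)c1` gives 6300 nM in the same test. These three values lie within the usual scatter of one another, so compound 1 stands level with the other two and the data do not rank them.

Compound 4 `COc1cc([C@@H](O)[C@@H](CO)Oc2c(OC)cc([C@@H](O)[C@H](O)CO)cc2OC)ccc1O` has not yet been measured. Its relation to compound 1 is simple: the two compounds have the same atoms and bonds and differ only in configuration as drawn: 1 of 4 stereo elements differ; a stereocentre at a saturated chain carbon is drawn S in compound 1 and R in compound 4 and no group leaves or enters.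

Among the compounds with values here, the only measured step between compounds that differ in one place is a 1.3-fold lower number from compound 2 to compound 3 (0.10 log units; within the scatter) for a methyl in place of hydrogen on an oxygen on a saturated carbon. That step stays within the scatter, but it is not a change of configuration, so it bears on the present question only weakly. Within the data shown here, no measured pair tests this stereocentre, and the data cannot exclude a larger effect from it. No step beyond the scatter is therefore expected in this assay for this change. The expected 1.1-fold lower number from compound 1 to compound 4 (0.03 log units; within the scatter) is small and carries no direction worth stating. Compound 4 is expected at 10000 nM with an estimated range from 4000 nM to 25000 nM as its bounds.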

Compound 4, half-maximal inhibitory concentration: 11800 nM
Estimate against measurement, compound 4: 1.2-fold (0.07 log units) below; the measured number falls inside the stated range.
By their numbers in this assay, from the lowest: compounds 3, 2, 1 and 4 (each within the scatter of the next).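

In this assay, turning over the stereocentre at a saturated chain carbon gives a 1.1-fold higher number from compound 1 to compound 4 (0.04 log units; within the scatter), so the first direct test of this centre finds no step beyond the scatter. Within the data shown here, the earlier compounds could not show this, as their only measured step, a 1.3-fold lower number from compound 2 to compound 3 (0.10 log units; within the scatter), concerned a methyl in place of hydrogen on an oxygen and left the configuration at this carbon untouched. The reading of the pair is a clean one, with nothing leaving or entering, and the drawn S and R forms at this centre cannot be told apart in this test, the whole of the structural difference being this: the fact that compounds 1 and 4 differ only in the configuration as drawn

On these data alone, the result speaks for one stereo element only, and whether turning over any of the other three would give a step beyond the scatter remains open. The compounds shown also leave open what an amine or a carboxylic acid on this saturated chain would do to the number, and whether this centre would stay as silent with either of those groups present.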